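Changing the Aryl Group in a Cytotoxic Series

A few compounds are considered here, and "the series" means these few. Any claim that something is new, unique, unknown or untested is made for them only; others in the source may bear on it.

Of the compounds shown here, three sharing one core have been tested in a functional assay on MDA-MB-231 cells (Homo sapiens) for cytotoxicity, read by MTT assay, with a stated time of 48 h; a higher number here means a weaker inhibitor, a lower number a stronger inhibitor. Compound 1 `COc1ccc(OC)c(C2=NOC(COc3ccc(-c4nnnn4-c4cc(OC)c(OC)c(OC)c4)cc3N)C2)c1` gives 3500 nM. Compound 2 `COc1ccc(C2=NOC(COc3ccc(-c4nnnn4-c4cc(OC)c(OC)c(OC)c4)cc3N)C2)cc1N` gives 3000 nM, and compound 3 `COc1ccc(C2=NOC(COc3ccc(-c4nnnn4-c4cc(OC)c(OC)c(OC)c4)cc3N)C2)cc1OC` gives 3570 nM. The three numbers sit close together: the step of a 1.2-fold lower number from compound 1 to compound 2 (0.07 log units; within the scatter), the step of a 1.0-fold higher number from compound 1 to compound 3 (0.01 log units; within the scatter) and the step of a 1.2-fold higher number from compound 2 to compound 3 (0.08 log units; within the scatter) all stay within the scatter, so compound 3 is not set apart from compounds 1 and 2 in this assay.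

Compound 4 `COc1cc(-n2nnnc2-c2ccc(OCC3CC(c4ccccc4F)=NO3)c(N)c2)cc(OC)c1OC` has not yet been measured. Relative to compound 3 the change is 2-fluorophenyl in place of 3,4-dimethoxyphenyl on a carbon with a double bond to nitrogen. Among the compounds with values here, none of the measured steps removes both methoxy groups or brings in a fluorine, so no step bears directly on this change. What the measured steps do show is that exchanging 2,5-dimethoxyphenyl for 3-amino-4-methoxyphenyl or for 3,4-dimethoxyphenyl on a carbon with a double bond to nitrogen, and exchanging amino for methoxy on an aromatic carbon, left the number within the scatter each time. On that basis the step of a 1.0-fold lower number from compound 3 to compound 4 (0.01 log units; within the scatter) is expected to stay within the scatter as well. For compound 4 the estimate is 3500 nM, with a range from 1500 nM to 8000 nM.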

Compound 4, half-maximal inhibitory concentration: 2400 nM
Estimate against measurement, compound 4: 1.5-fold (0.16 log units) above; measured number inside the range.
By their numbers in this assay, from the lowest: compounds 4, 2, 1 and 3 (each within the scatter of the next).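

In this assay the number stayed within the scatter when 2-fluorophenyl took this place on the carbon with a double bond to nitrogen: the step of a 1.5-fold lower number from compound 3 to compound 4 (0.17 log units; within the scatter) and the step of a 1.3-fold lower number from compound 2 to compound 4 (0.10 log units; within the scatter) and the step of a 1.5-fold lower number from compound 1 to compound 4 (0.16 log units; within the scatter) show no separation from any of the three earlier compounds. Compounds 1, 2 and 3 all carry a methoxy group on this aryl ring, whereas compound 4 carries none, so the position is now seen to hold both 3,4-dimethoxyphenyl, with 10 heavy atoms and 2 hydrogen-bond acceptors, and 2-fluorophenyl, with 7 heavy atoms and 0 hydrogen-bond acceptors, without a difference beyond the scatter. Nothing presented here offers an explanation for this flat result.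

What the compounds shown leave open is whether the number would also stay within the scatter with a cyclohexyl ring, a longer alkyl chain or a phenyl ring bearing a carboxylic acid at this place. All four compounds also keep the same amino group on the shared core, so the effect of replacing that amine with an acetamide remains an open question.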